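A few compounds are considered here, and "the series" means these few. Any claim that something is new, unique, unknown or untested is made for them only; others in the source may bear on it.

In a functional assay on PC-3 cells (Homo sapiens) for antiproliferative activity, read by MTT assay, with a stated time of 72 h (on this read-out higher numbers stand for weaker inhibition and lower numbers for stronger inhibition), compound 1 (`CCCCCCCCCCCNC[C@@H]1OC[C@H](N)[C@@H]1O`) gives 3330 nM and compound 2 (`CCCCCCCCCCCCNC[C@@H]1OC[C@H](N)[C@H]1O`) gives 2380 nM so the two stand within the usual scatter of each other. Compound 3 (`CCCCCCCCCCCCCCNC[C@@H]1OC[C@H](N)[C@H]1O`) differs from compound 2 by one change (ethyl in place of hydrogen on a saturated chain carbon, ten or more bonds along the chain from an amine nitrogen) which is ethyl in place of hydrogen on a saturated chain carbon, ten or more bonds along the chain from an amine nitrogen. Going by the values given here, no measured step of this kind is available, so no shift beyond the scatter is expected in this assay here. The estimated change a 1.1-fold higher number from compound 2 to compound 3 (0.02 log units; within the scatter) is small. The estimated value for compound 3 is 2500 nM with 1200 nM to 5000 nM as the expected range.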

Compound 3, half-maximal inhibitory concentration: 1990 nM
Beside the measured number, compound 3's estimate is 1.3-fold (0.10 log units) above it; measured number inside the range.
By their numbers in this assay, from the lowest: compounds 3, 2 and 1 (each within the scatter of the next).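

In this assay, going by these compounds alone, the only measured step of this kind, a 1.2-fold lower number from compound 2 to compound 3 (0.08 log units; within the scatter) for ethyl in place of hydrogen on a saturated chain carbon, ten or more bonds along the chain from an amine nitrogen, shows that this change moves the number no further than the scatter. So this place on the chain accepts two more carbons without a readable shift in this assay. Nothing measured here offers an explanation for this result. On these data alone, whether a longer chain, or a carboxylic acid or an amine at this same place, would also leave the number within the scatter stays open.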